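Naphthalen-1-yl thioether replacing phenyl thioether in compound 1

The source may report more compounds than this note shows. Statements on the series, on what has been measured and on what is new or still open speak of the compounds shown alone.

Compound 1 `CS(=O)(=O)c1ccc(-c2nc3ccccn3c2Sc2ccccc2)cc1` carries a methylsulfonyl group on an aromatic carbon and a phenyl group on the sulfur of the shared core. In a functional assay on SK-MEL-28 cells (Homo sapiens) for inhibition, read by MTT assay, with a stated time of 48 h (a higher number here means a weaker inhibitor, a lower number a stronger inhibitor), compound 1 gives 61900 nM. Compound 2 `COc1ccc(-c2nc3ccccn3c2Sc2ccccc2)cc1`, with methoxy in place of methylsulfonyl, gives in this assay 83900 nM; compound 3 `CSc1ccc(-c2nc3ccccn3c2Sc2ccccc2)cc1`, with methylsulfanyl in that place, gives 67700 nM. Of the three numbers that of compound 1 is the lowest, but a 1.4-fold higher number from compound 1 to compound 2 (0.13 log units; within the scatter) and a 1.1-fold higher number from compound 1 to compound 3 (0.04 log units; within the scatter) are both within the scatter, as is a 1.2-fold lower number from compound 2 to compound 3 (0.09 log units; within the scatter), so nothing separates the three compounds.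

Compound 4 `CS(=O)(=O)c1ccc(-c2nc3ccccn3c2Sc2cccc3ccccc23)cc1` differs from compound 1 by naphthalen-1-yl in place of phenyl on a sulfur. Within the data shown here, none of the measured steps touches the group on the sulfur: all three exchange the substituent on an aromatic carbon, and all three stay within the scatter. Among the measured compounds shown here, no measured step bears on the change from phenyl to naphthalen-1-yl, and no direction can be drawn from the series. For compound 4 the number in this assay is therefore expected near that of compound 1, with a 1.1-fold lower number from compound 1 to compound 4 (0.05 log units; within the scatter) expected to remain within the scatter, and with wide uncertainty. The estimate for compound 4 is 55000 nM, with a range from 15000 nM to 200000 nM.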

Compound 4, half-maximal inhibitory concentration: 67300 nM
For compound 4 the middle estimate is 1.2-fold (0.09 log units) below the measured one; the range from low to high includes it.
By their numbers in this assay, from the lowest: compounds 1, 4, 3 and 2 (each within the scatter of the next).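

Among these compounds, the first measured step at the sulfur, with methylsulfonyl held in place on the aromatic carbon, is a 1.1-fold higher number from compound 1 to compound 4 (0.04 log units; within the scatter) in this assay. The earlier steps shown here all exchanged the substituent on an aromatic carbon, so they left the sulfur position untested; this step shows that phenyl, with 6 heavy atoms and one six-membered aromatic ring, and naphthalen-1-yl, with 10 heavy atoms and 2 such rings, cannot be told apart at this position in this pair. Nothing available gives a reason for this result, and no measurement beyond the numbers themselves bears on it.

Still open, on these data alone, is whether naphthalen-1-yl on the sulfur would give the same picture with methoxy or methylsulfanyl on the aromatic carbon, since this one pair carries methylsulfonyl only. Also open, as far as these compounds go, is whether a group of another kind on the sulfur, such as a benzyl group, a longer alkyl chain, or a phenyl ring bearing an amine or a carboxylic acid, would produce a step beyond the scatter in this assay.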